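The source may hold more compounds than are shown below. What is called first, only, known or untested is meant among the compounds shown, and "the series" means these compounds.

Working notes on a small set of protein disulfide-isomerase inhibitors, all tested in an assay for inhibition of protein disulfide-isomerase (Homo sapiens), with a stated time of 1 h; a higher number here means a weaker inhibitor, a lower number a stronger inhibitor.

Compound 1 `Oc1c(C(c2ccc(F)cc2)N2CCCCC2)ccc2scnc12` gives 570 nM in this assay. Compound 2 `Cc1ccc(C(Nc2ccccn2)c2ccc3cccnc3c2O)cc1` gives 460 nM, and compound 3 `Cc1ccnc(NC(c2ccc(OCc3ccccc3)cc2)c2ccc3cccnc3c2O)c1` gives 620 nM. Compound 2 thus sits at the smallest of the three numbers, but the gaps to compound 1 and to compound 3 both lie within the scatter of repeated measurements, so the three compounds cannot be ranked against one another on these values. Compound 2 and compound 3 share a core and differ at the group on the saturated chain carbon and at the pyridine side; their two values show no separation beyond the scatter.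

Compound 4 `Oc1c(C(Nc2ccccn2)c2ccccc2Cl)ccc2cccnc12` has not yet been measured. It differs from compound 2 by a single change: 2-chlorophenyl in place of 4-methylphenyl on a saturated chain carbon bound to an aromatic carbon and a nitrogen on an aromatic ring. Among the compounds with values here, no pair of measured compounds in the set differs in one place, so there is no measured step to lean on for this change. Given that the group on the saturated chain carbon varies between compound 2 and compound 3 with no separation beyond the scatter, the step is expected to be small in this assay, with no direction beyond the scatter favoured. Compound 4 is therefore estimated at 600 nM in this assay, in the range 250 nM to 1500 nM, which means an expected step of a 1.3-fold higher number from compound 2 to compound 4 (0.12 log units; within the scatter).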

Compound 4, half-maximal inhibitory concentration: 500 nM
Beside the measured number, compound 4's estimate is 1.2-fold (0.08 log units) above it; the measured number falls inside the stated range.
By their numbers in this assay, from the lowest: compounds 2, 4, 1 and 3 (each within the scatter of the next).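

Within the data shown here, the step of a 1.1-fold higher number from compound 2 to compound 4 (0.04 log units; within the scatter) in this assay is the only measured change in one place in this set, and it gives direct evidence that 2-chlorophenyl can take the place of 4-methylphenyl on a saturated chain carbon bound to an aromatic carbon and a nitrogen on an aromatic ring with no separation beyond the scatter. The comparison between compound 2 and compound 3 could not show this, as those two compounds also differ at the pyridine side. The two groups have the same heavy-atom count, one six-membered aromatic ring of carbon only, no hydrogen-bond donors or acceptors and no net charge, so the pair tests only a narrow change at this position, and no supporting data bear on the result.

On these data alone, whether a group of a different kind at this position, such as a carboxylic acid, an amine or a longer alkyl chain, would produce a step beyond the scatter remains open. The other places on the core shared by compound 2 and compound 4 also remain unresolved, including the effect on the number of a methoxy group in place of the hydroxyl.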